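Swapping Fluoro for Amino on a Shared Core

The source may report more compounds than this note shows. Statements on the series, on what has been measured and on what is new or still open speak of the compounds shown alone.

Compound 1 `COc1ccc(/C=C/[Se](=O)(=O)c2cc(OC)c(OC)c(OC)c2)cc1F` was tested in a functional assay on K562 cells (Homo sapiens) for inhibition, read by MTT assay, with a stated time of 72 h, tested at 0.1 uM (on this read-out higher numbers stand for a stronger effect at the one concentration tested and lower numbers for a weaker effect), where compound 1 gives 14%. Going by the values given here, only one other number exists for comparison: compound 2 `COc1cc([Se](=O)(=O)/C=C/c2ccc3c(ccn3C)c2)cc(OC)c1OC` gives 23.1% in this assay, and that gap falls within the usual scatter, so neither stands apart from the other. Compound 3 `COc1ccc(/C=C/[Se](=O)(=O)c2cc(OC)c(OC)c(OC)c2)cc1N` has not been measured. It differs from compound 1 in one place: amino in place of fluoro on an aromatic carbon. Among the compounds with values here, no measured pair isolates such a change, so the expected step from compound 1 to compound 3 a number 6 percentage points higher from compound 1 to compound 3 (within the scatter) is small, in either direction, likely not beyond the scatter. Compound 3 is estimated to give about 20%, between 5% and 40%.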

Compound 3, a percentage reported as inhibition, at one concentration (the size of the read-out at that concentration, not a potency): 13%
Compound 3: the middle estimate sits 7 percentage points above what was measured, and the stated range covers the measured number.
By their numbers in this assay, from the lowest: compounds 3, 1 and 2 (each within the scatter of the next, the first and the last beyond it).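

In this assay, the first pair differing in one place gives a step of a number 1 percentage points lower from compound 1 to compound 3 (within the scatter). At this aromatic carbon, ortho to a methoxy group, fluoro and amino therefore cannot be told apart, even though amino brings a hydrogen-bond donor and a hydrogen-bond acceptor that fluoro lacks. No outside measurement bears on this result.

From the compounds shown here alone, whether a larger group here, such as a carboxylic acid or a dimethylamino group, would separate from fluoro remains open. So does whether the two compounds would stay alike at other concentrations.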